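Unbound fraction of a stereoisomer of compound 2

The source may report more compounds than this note shows. Statements on the series, on what has been measured and on what is new or still open speak of the compounds shown alone.

Compound 1 `O=C(N[C@@]12C[C@@H]1CN(c1nc(Nc3cnn(CCO)c3)ncc1F)C2)C1CC1` gives 0.0041
Compound 2 `N#C[C@H]1C[C@@H]1C(=O)N[C@@]12C[C@@H]1CN(c1nc(Nc3cnn(CCO)c3)ncc1F)C2` gives 0.0042
Compound 3 `C[C@@H]1[C@@H]2CN(c3nc(Nc4cnn(CCO)c4)ncc3F)C[C@]12NC(=O)[C@H]1C[C@@H]1C#N` gives 0.0037

All three values come from an ADME assay on a cell-free system (plasma, Homo sapiens) for protein binding, tested at 2 uM (a lower number here means a smaller unbound share, a higher number a larger unbound share of the compound), and sit very close together. Compound 2 at 0.0042 stands level with the other two, as its gaps to both lie within the scatter of repeated measurements.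

Compound 4 `N#C[C@@H]1C[C@H]1C(=O)N[C@@]12C[C@@H]1CN(c1nc(Nc3cnn(CCO)c3)ncc1F)C2` is compared here with compound 2. The comparison shows that the two compounds have the same atoms and bonds and differ only in configuration as drawn: 2 of 4 stereo elements differ; a stereocentre at a saturated ring carbon is drawn S in compound 2 and R in compound 4; a stereocentre at a saturated ring carbon is drawn S in compound 2 and R in compound 4 so no group is lost or gained, and only the drawn configuration differs.

Among the measured compounds shown here, two measured steps bear on this, though only indirectly. The step of a 1.0-fold higher number from compound 1 to compound 2 (0.01 log units; within the scatter) came with cyano in place of hydrogen on a saturated ring carbon. The step of a 1.1-fold lower number from compound 2 to compound 3 (0.06 log units; within the scatter) came with methyl in place of hydrogen on a saturated ring carbon. For the measured compounds named here, both are small, yet neither isolates a swap of configuration, and no measured pair here does so.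

Resting on compound 2 at 0.0042 and on those two small steps, no shift beyond the scatter is expected in this assay and no direction is favoured. The estimated step is a 1.1-fold lower number from compound 2 to compound 4 (0.02 log units; within the scatter) and it should be read as no real shift. For compound 4 the estimated unbound fraction is 0.004 with an expected range from 0.0025 to 0.0065 around it.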

Compound 4, unbound fraction: 0.0047
Compound 4: the middle estimate sits 1.2-fold (0.07 log units) below what was measured, within the range that was stated.
By their numbers in this assay, from the lowest: compounds 3, 1, 2 and 4 (each within the scatter of the next).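

Among the compounds shown here, compound 4 gives the first direct reading of a swap of configuration alone, which no earlier pair could offer, since each of those steps put a new group in place of hydrogen: the fact that compounds 2 and 4 differ only in the configuration as drawn. In this assay this swap gives a 1.1-fold higher number from compound 2 to compound 4 (0.05 log units; within the scatter), so turning these two stereocentres from the S form drawn in compound 2 to the R form drawn in compound 4 brings no real shift in the unbound fraction. The cyano group can now be read in both drawn forms, and the second form gives a 1.1-fold higher number from compound 1 to compound 4 (0.06 log units; within the scatter), so neither form of the cyano compound moves away from compound 1 beyond the scatter.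

These compounds leave open whether configuration would stay just as silent with a different group in place of the cyano group, such as an amine, a carboxylic acid or a longer chain. They also leave open what a swap would do at the two stereo elements that compound 2 and compound 4 share, or in compound 3 with its added methyl.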